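Moving the chlorine: an estimate for compound 3

The compounds below may be only part of what the source reports. "The series", "measured", "known", "first", "only" and "open" are said of these compounds alone.

Compound 1 `NS(=O)(=O)c1ccc(N2N=C(c3ccc(Oc4ccccc4)cc3)CC2c2ccccc2Cl)cc1` is one of two compounds that have been tested in an ADME assay on MT4 cells (Homo sapiens) for cytotoxicity, read by MTT assay, with a stated time of 96 h; on this read-out lower numbers stand for higher toxicity in this test and higher numbers for lower toxicity in this test. In this assay compound 1 gives 40000 nM. The other measured compound, compound 2 `Cc1cccc(C2CC(c3ccc(OCc4ccccc4)cc3)=NN2c2ccc(S(N)(=O)=O)cc2)c1`, gives 44000 nM in this assay. Of these two numbers, compound 1 has the smaller, but the gap to compound 2 falls within the usual scatter of repeated measurements, so the two compounds cannot be told apart on this read-out.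

Compound 3 `NS(=O)(=O)c1ccc(N2N=C(c3ccc(Oc4ccccc4)cc3)CC2c2cccc(Cl)c2)cc1` has not yet been measured in this assay. It differs from compound 1 by 3-chlorophenyl in place of 2-chlorophenyl on a saturated ring carbon. For the measured compounds named here, no pair of measured compounds differs in one place only, so no measured step shows what this change does; compound 2 differs from compound 1 in more than one place at once. With the same atoms joined differently and with the two measured compounds sitting close together, the step from compound 1 to compound 3 is expected to stay within the scatter, in either direction, so that no change at the digits printed from compound 1 to compound 3 (within the scatter) is the estimated outcome. Compound 3 is therefore expected to give about 40000 nM in this assay, with a plausible range from 20000 nM to 80000 nM.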

Compound 3, half-maximal cytotoxic concentration: 8000 nM
Estimate against measurement, compound 3: 5.0-fold (0.70 log units) above; measured number outside the range, below it.
By their numbers in this assay, from the lowest: compound 3; then compounds 1 and 2 (each within the scatter of the next).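

Moving the chlorine so that 3-chlorophenyl stands in place of 2-chlorophenyl on the saturated ring carbon gives a 5.0-fold lower number from compound 1 to compound 3 (0.70 log units; beyond the scatter) in this assay. The read-out at this position therefore depends on where the chlorine sits on the phenyl ring, even though the two groups hold the same atoms and the rest of the molecule is unchanged. Compound 1 and compound 2 differ in more than one place and lie within the scatter of each other, so they gave no view of this position on its own; nothing in the data available explains the step.

The compounds shown leave open whether the step belongs to the chlorine or to the placing of any group on this phenyl ring, as 3-fluorophenyl or 3-methoxyphenyl on the same saturated ring carbon could show, and how 4-chlorophenyl there would compare with 2-chlorophenyl and 3-chlorophenyl. Going by these compounds, whether the same move of the chlorine would give a step of similar size on the core of compound 2, with its benzyloxy group, also stays open.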